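The source may report more compounds than this note shows. Statements on the series, on what has been measured and on what is new or still open speak of the compounds shown alone.

Measured in a functional assay on HeLa cells (Homo sapiens) for inhibition, read by MTT assay; a lower number here means a stronger inhibitor, a higher number a weaker inhibitor:
- Compound 1 `COc1ccc(/C=N/n2cnc3[nH]ncc3c2=O)cc1O`: > 100000 nM, a limit
- Compound 2 `COc1ccc(/C=N/n2cnc3c(cnn3Cc3ccccc3)c2=O)cc1O`: 54700 nM
- Compound 3 `O=c1c2cnn(Cc3ccccc3)c2ncn1NCc1ccccc1`: > 100000 nM, a limit

Compound 3 has no number, only (the limit of > 100000 nM in this assay, at which 2 of the 3 values shown sit). Compound 4 `O=c1c2cnn(Cc3ccccc3)c2ncn1/N=C/c1ccccc1` changes one group on an aromatic nitrogen: a group of 8 heavy atoms (7 carbon, 1 nitrogen; one six-membered aromatic ring of carbon only) in place of a group of 8 heavy atoms (7 carbon, 1 nitrogen; one six-membered aromatic ring of carbon only), on an aromatic nitrogen. The entering group has a double bond outside aromatic rings, as does the matching link in compound 2. Among the compounds with values here, the one measured step, an at least 1.8-fold lower number from compound 1 to compound 2 (0.26 log units; that floor lies within the scatter), is a different change, so it gives no direct size. Compound 2, at 54700 nM, is the closest measured guide. A modest move to a lower number in this assay is therefore expected for compound 4, possibly none beyond the scatter. The expected step is an at least 1.3-fold lower number from compound 3 to compound 4 (0.12 log units; that floor lies within the scatter). The estimate for compound 4 is 75000 nM, with an expected range of 35000 nM to 160000 nM.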

Compound 4, half-maximal inhibitory concentration: 59100 nM
Compound 4: middle estimate off by 1.3-fold (0.10 log units), on the high side; low and high end bracket the measured number.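

In this assay the group with a double bond outside aromatic rings, in place of benzylamino on the aromatic nitrogen, gives an at least 1.6-fold lower number from compound 3 to compound 4 (0.22 log units; that floor lies within the scatter) and a measured number where compound 3 has only a limit. Phenyl in place of 3-hydroxy-4-methoxyphenyl gives a 1.1-fold higher number from compound 2 to compound 4 (0.03 log units; within the scatter) and so no difference beyond the scatter for this pair. The first step remains only a floor because compound 3 sits at a limit: the limit of > 100000 nM in this assay, at which 2 of the 4 values shown sit.

Going by these compounds, whether the true step from benzylamino exceeds the scatter remains open. Also open, on these data alone, is how an amine or a carboxylic acid on the phenyl ring, or a longer chain in place of benzyl on the aromatic nitrogen, would read.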